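Methoxy to chloro on the pyrazoline aryl of compound 3

This account rests on a few compounds, and the source may have more. Where it says the series, first, only, none or still open, it means among the compounds named here.

Compound 1 `O=C1N=C(N2N=C(c3ccccc3)CC2c2ccccc2O)S/C1=C1/C(=O)Nc2ccccc21` gives 4400 nM in a functional assay on cells (Melanoma cell, Homo sapiens) for cytotoxicity, read by sulforhodamine B assay, with a stated time of 48 h; on this read-out higher numbers stand for weaker inhibition of growth and lower numbers for stronger inhibition of growth. Compound 2 `COc1ccc(C2=NN(C3=NC(=O)/C(=C4\C(=O)Nc5ccc(Br)cc54)S3)C(c3ccc(OC)cc3)C2)cc1` gives 410 nM, and compound 3 `COc1ccc(C2=NN(C3=NC(=O)/C(=C4\C(=O)Nc5ccc(Cl)cc54)S3)C(c3ccc(OC)cc3)C2)cc1` gives 380 nM, the lowest of the three numbers, with compound 2 within the scatter of it and compound 1 well apart. For the measured compounds named here, the only single-change step measured, a 1.1-fold lower number from compound 2 to compound 3 (0.03 log units; within the scatter), lies within the scatter. Compound 4 `COc1ccc(C2=NN(C3=NC(=O)/C(=C4\C(=O)Nc5ccc(Cl)cc54)S3)C(c3ccc(Cl)cc3)C2)cc1` differs from compound 3 by chloro in place of methoxy on an aromatic carbon. Going by the values given here, no measured step bears on this change, so nothing indicates a direction; the expected step of a 1.1-fold higher number from compound 3 to compound 4 (0.02 log units; within the scatter) is within the scatter. For compound 4 the estimate is 400 nM, with a range from 150 nM to 1100 nM.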

Compound 4, concentration for total growth inhibition: 440 nM
For compound 4 the middle estimate is 1.1-fold (0.04 log units) below the measured one; low and high end bracket the measured number.
By their numbers in this assay, from the lowest: compounds 3, 2 and 4 (each within the scatter of the next); then compound 1.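

The first step read at this aryl group, 4-methoxyphenyl to 4-chlorophenyl, is a 1.2-fold higher number from compound 3 to compound 4 (0.06 log units; within the scatter) in this assay. Compound 3 and compound 4 thus stand within the scatter of each other, so at this place, on this core, chloro and methoxy cannot be told apart by this read-out. No supporting data bear on why the two groups read alike.

Going by these compounds, whether an amine or a carboxylic acid at this place would read the same remains open. So does the effect of the same change on the second 4-methoxyphenyl group.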